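Thiophen-3-yl for thiophen-2-yl: working notes on the series

A few compounds are considered here, and "the series" means these few. Any claim that something is new, unique, unknown or untested is made for them only; others in the source may bear on it.

Measured in an ADME assay on MRC5 cells (Homo sapiens) for cytotoxicity, read by MTT assay, with a stated time of 72 h; a lower number here means that less compound is tolerated, a higher number that more compound is tolerated:
- Compound 1 `CCCCCCCCCCCCCCCCCCOP(=O)(O)OC[C@H]1O[C@@H](n2ccc3c(-c4ccccc4)ncnc32)[C@H](O)[C@@H]1O`: > 50000 nM (a limit of the assay)
- Compound 2 `CCCCCCCCCCCCCCCCCCOP(=O)(O)OC[C@H]1O[C@@H](n2ccc3c(-c4ccco4)ncnc32)[C@H](O)[C@@H]1O`: 45300 nM
- Compound 3 `CCCCCCCCCCCCCCCCCCOP(=O)(O)OC[C@H]1O[C@@H](n2ccc3c(-c4cccs4)ncnc32)[C@H](O)[C@@H]1O`: "not determined" (no result reported)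

Compound 3 has no number of its own: its entry reads "not determined" (no result reported), so it offers no anchor for the next step. Only the neighbouring compounds give a frame. Compound 1 sits at the limit of > 50000 nM in this assay, at which 1 of the 3 values shown sits. Compound 2 is the only one of the three with a plain number, 45300 nM.

Compound 4 `CCCCCCCCCCCCCCCCCCOP(=O)(O)OC[C@H]1O[C@@H](n2ccc3c(-c4ccsc4)ncnc32)[C@H](O)[C@@H]1O` comes from compound 3 by a single exchange on an aromatic carbon, (thiophen-3-yl in place of thiophen-2-yl on an aromatic carbon).

Within the data shown here, one measured step bears on this, an exchange at the same carbon of furan-2-yl in place of phenyl: an at least 1.1-fold lower number from compound 1 to compound 2 (0.04 log units; that floor lies within the scatter). Among the measured compounds shown here, its size is only a floor, and no step involving either thiophene has been measured. With that little to go on, no change beyond the scatter is expected in this assay from this exchange, and no direction can be named. Compound 4 is therefore expected to read close to compound 2 at 45300 nM. A report of only a limit for compound 4 would be no surprise.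

For compound 4 the estimated value is 45000 nM, with an expected range of 20000 nM to 50000 nM.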

Compound 4, half-maximal cytotoxic concentration: > 50000 nM
Compound 4 gave a limit, no number (the forecaster's own chance of this, stated with the estimate: 45%); middle value at least 1.1-fold (0.04 log units) away from the limit.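

Among these compounds, with compound 4, a thiophene at this carbon gets a reading in this assay for the first time, and that reading is a limit of the assay and not a number. Thiophen-3-yl in place of furan-2-yl gives an at least 1.1-fold higher number from compound 2 to compound 4 (0.04 log units; that floor lies within the scatter), so this exchange does not separate the two five-membered aromatic rings on the core of compound 2. Compound 1 and compound 4 both end in limits, so the step between phenyl and thiophen-3-yl cannot be read, and the series now has this ceiling recurring at this carbon: the limit of > 50000 nM in this assay, at which 2 of the 4 values shown sit.

The exchange named in the title, thiophen-3-yl for thiophen-2-yl, stays unread, with compound 3 reporting no result and compound 4 only a limit. Also open, going by these compounds, is whether a group of another kind on this carbon, such as an amine or a carboxylic acid, would give a number in this assay that stands apart from compound 2 by more than the scatter.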